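Shifting a Fluorine Atom Across Two Related Cores

The source may report more compounds than this note shows. Statements on the series, on what has been measured and on what is new or still open speak of the compounds shown alone.

Four compounds share one framework and differ in two places. Compound 1, `COc1ccc(C(=O)/C=C/c2ccc(OCc3cn(Cc4cccc(F)c4)nn3)cc2)cc1`, is the reference point; in a functional assay on A549 cells (Homo sapiens) for inhibition, read by MTT assay, with a stated time of 48 h, tested at 10 uM (a higher number here means more inhibition of growth at the concentration tested, a lower number less inhibition of growth), compound 1 gives 56%. Compound 2, `COc1ccc(C(=O)/C=C/c2ccc(OCc3cn(Cc4ccc(F)cc4)nn3)cc2)cc1`, differs from it by 4-fluorophenyl in place of 3-fluorophenyl on a saturated chain carbon bound to an aromatic nitrogen, and in this assay compound 2 gives 33%; the step is a number 23 percentage points lower from compound 1 to compound 2 (beyond the scatter). Compound 3, `O=C(/C=C/c1ccc(OCc2cn(Cc3cccc(F)c3)nn2)cc1)c1ccc([N+](=O)[O-])cc1`, differs from compound 1 in another way, (nitro in place of methoxy on an aromatic carbon); in this assay compound 3 gives 33%, and the step is a number 23 percentage points lower from compound 1 to compound 3 (beyond the scatter). Compound 2 and compound 3 stand level at the digits recorded, and together they are the lowest of the three numbers.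

Compound 4, `O=C(/C=C/c1ccc(OCc2cn(Cc3ccc(F)cc3)nn2)cc1)c1ccc([N+](=O)[O-])cc1`, is not yet measured. It stands to compound 3 as compound 2 stands to compound 1: 4-fluorophenyl in place of 3-fluorophenyl on a saturated chain carbon bound to an aromatic nitrogen. The place of the change is the same in both pairs, so this is the same change, carried out on the core of compound 3 rather than that of compound 1; how the two cores differ has been told above in the comparison of compound 3 with compound 1.

For the measured compounds named here, the only guide to the outcome is the drop seen once before, from compound 1 to compound 2, a number 23 percentage points lower from compound 1 to compound 2 (beyond the scatter). If the same change behaves the same way on the second core, compound 4 should fall further, and the expected step is a number 18 percentage points lower from compound 3 to compound 4 (beyond the scatter). Compound 3 already starts low, so there is less room to fall, and a single earlier example is a thin basis. For compound 4 in this assay the expected value is 15%, most likely between 0% and 35%.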

Compound 4, percent growth inhibition at one concentration: 34%
The estimate for compound 4 lay 19 percentage points below the measured number, within the range that was stated.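

In this assay, the switch from 3-fluorobenzyl to 4-fluorobenzyl on the core of compound 3 gives a number 1 percentage points higher from compound 3 to compound 4 (within the scatter), so the drop seen on the core of compound 1 does not carry over, and the two steps clearly differ: the same change on two cores in this assay, a number 23 percentage points lower (beyond the scatter) from compound 1 to compound 2 and a number 1 percentage points higher (within the scatter) from compound 3 to compound 4, 24 percentage points apart, beyond the scatter of two such steps

Read the other way, nitro in place of methoxy gives a number 1 percentage points higher from compound 2 to compound 4 (within the scatter), so this change does not repeat its earlier drop once the fluorine is in the 4-fluorophenyl group: the same change on two cores in this assay, a number 23 percentage points lower (beyond the scatter) from compound 1 to compound 3 and a number 1 percentage points higher (within the scatter) from compound 2 to compound 4, 24 percentage points apart, beyond the scatter of two such steps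

Together these show that the two changes do not simply add up in this small set, so a step measured on one core could not be relied on for the other; they do not show why this happens, and with only these four compounds they support no rule for the wider series.

The compounds shown leave open how the fluorine switch would behave with other groups in place of methoxy or nitro, such as an amine or a carboxylic acid. On these data alone, it also remains open whether a plain phenyl or a chlorophenyl in place of the fluorophenyl would follow the same pattern on either core.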